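This account rests on a few compounds, and the source may have more. Where it says the series, first, only, none or still open, it means among the compounds named here.

Compound 1 `COc1ccc(-n2nncc2CN2C(=O)C3(C(C#N)=C(N)Oc4c3c3nc5ccccc5nc3c3ccccc43)c3ccccc32)cc1`: in a functional assay on HCT-116 cells (Homo sapiens) for antiproliferative activity, read by MTT assay, with a stated time of 48 h (on this read-out lower numbers stand for stronger inhibition and higher numbers for weaker inhibition), compound 1 gives > 50000 nM, a limit of the assay rather than a number.
Compound 2 `N#CC1=C(N)Oc2c(c3nc4ccccc4nc3c3ccccc23)C12C(=O)N(Cc1cnnn1-c1ccc([N+](=O)[O-])cc1)c1ccccc12`: in this assay compound 2 gives > 50000 nM, again only a limit.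
Compound 3 `Cc1ccccc1-n1nncc1CN1C(=O)C2(C(C#N)=C(N)Oc3c(N)cc4nc5ccccc5nc4c32)c2ccccc21`: in this assay compound 3 gives > 50000 nM, also a limit.

Compound 3 therefore stands at the limit of > 50000 nM in this assay, at which 3 of the 3 values shown sit, so no measured value separates it from the other two. Among the measured compounds shown here, the one step between measured compounds, a step that the two limits leave unreadable from compound 1 to compound 2, is hidden by the limits and says nothing about size or direction. Compound 4 `Cc1cccc(-n2nncc2CN2C(=O)C3(C(C#N)=C(N)Oc4c(N)cc5nc6ccccc6nc5c43)c3ccccc32)c1` differs from compound 3 only by 3-methylphenyl in place of 2-methylphenyl on an aromatic nitrogen. For the measured compounds named here, no measured step touches this kind of change, so no shift beyond the scatter is expected, and the step that the limit leaves unreadable from compound 3 to compound 4 is estimated as essentially none. Compound 4 is expected to give about 60000 nM, within 20000 nM to 200000 nM, most likely reported again as a limit.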

Compound 4, half-maximal inhibitory concentration: > 50000 nM
Compound 4 gave a limit, no number; the forecaster's own chance of this, stated with the estimate: 85%; the middle value lies beyond the limit too.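

Compound 3 and compound 4 both give only a limit, not a number, so no step can be read between them: the limit of > 50000 nM in this assay, at which 4 of the 4 values shown sit. The compounds shown leave open whether swapping 2-methylphenyl for 3-methylphenyl changes activity at all.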